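The source may report more compounds than this note shows. Statements on the series, on what has been measured and on what is new or still open speak of the compounds shown alone.

Three compounds share one core and differ only in the group carried by the amide-type nitrogen. Compound 1 `CCNC(=O)CC1CCc2cc(OC)c(OC)cc21` gives 33.3% in a functional assay on the whole organism (strain Wistar) for inhibition, with Rattus norvegicus as the target, read by paw edema, with stated times of 60 min and 24 h, at a dose of 100 mg/kg by the oral route; on this read-out higher numbers stand for more inhibition at the one dose given (going by the name of the read-out) and lower numbers for less inhibition. Compound 2 `CCCNC(=O)CC1CCc2cc(OC)c(OC)cc21` gives 26.7% in this assay, and compound 3 `COc1cc2c(cc1OC)C(CC(=O)NC(C)C)CC2` gives 30%. Compound 3 stands among the other two without separation: its value differs from that of compound 1 and from that of compound 2 by less than the scatter, and all three numbers lie within the scatter of one another. Compound 4 `CCCCCCNC(=O)CC1CCc2cc(OC)c(OC)cc21` is not yet measured. It differs from compound 3 by hexyl in place of isopropyl on an amide-type nitrogen. Among the compounds with values here, the steps that bear on this change are a number 3.3 percentage points higher from compound 2 to compound 3 (within the scatter), a number 6.6 percentage points lower from compound 1 to compound 2 (within the scatter) and a number 3.3 percentage points lower from compound 1 to compound 3 (within the scatter), each an alteration of the group on the amide-type nitrogen and each within the scatter. Within the data shown here, no measured step covers a chain as long as hexyl, so the expectation rests on these small steps alone. The step of a number 2 percentage points lower from compound 3 to compound 4 (within the scatter) is expected to stay within the scatter. Compound 4 is therefore estimated at 28%, with a range from 12% to 42%.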

Compound 4, a percentage reported as inhibition, in the whole organism at one dose (the size of the read-out at that dose, not a potency): 45.5%
Beside the measured number, compound 4's estimate is 17.5 percentage points below it, outside the stated range (above it).
By their numbers in this assay, from the lowest: compounds 2, 3 and 1 (each within the scatter of the next); then compound 4.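

On the amide-type nitrogen, the shorter groups of compounds 1, 2 and 3 could not be told apart, whereas hexyl in place of isopropyl gives a number 15.5 percentage points higher from compound 3 to compound 4 (beyond the scatter) in this assay. The hexyl compound also separates from the other two, with a number 18.8 percentage points higher from compound 2 to compound 4 (beyond the scatter) and a number 12.2 percentage points higher from compound 1 to compound 4 (beyond the scatter), so this position can affect the read-out once the group on the nitrogen is a hexyl chain. Nothing available explains why the hexyl chain gives this result.

The compounds shown leave open where along the chain the separation sets in, since butyl and pentyl do not appear among them, and whether a longer chain such as octyl would go further or fall back. They also leave open whether a ring such as cyclohexyl or phenyl on the same nitrogen would match hexyl.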